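Swapping the hydroxy of compound 3 for a triazole

This account rests on a few compounds, and the source may have more. Where it says the series, first, only, none or still open, it means among the compounds named here.

Results so far in an ADME assay on microsomes from liver (Homo sapiens) for metabolic stability, read by LC-MS, with NADPH named in the record, with a stated time of 60 min, tested at 1 uM, in the absence of a further agent (a lower number here means that less of the compound is left, a higher number that more of the compound is left), are as follows:
- Compound 1 `COc1ccc(-c2c(C)nc3c(N4CC[C@@H](NS(C)(=O)=O)C4)cc(C)nn23)cc1OC` shows > 95% as a limit
- Compound 2 `COc1ccc(-c2c(C)nc3c(N4CC[C@@H](NS(=O)(=O)c5ccc(C#N)cc5)C4)cc(C)nn23)cc1OC` shows > 95% as a limit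
- Compound 3 `COc1ccc(-c2c(C)nc3c(N4CC[C@@H](O)C4)cc(C)nn23)cc1OC` shows > 95% as a limit

Compound 3 therefore stands at > 95% as a limit and not as a number. Compound 4 (`COc1ccc(-c2c(C)nc3c(N4CC[C@@H](n5cc(-c6ccccc6)nn5)C4)cc(C)nn23)cc1OC`) has 4-phenyl-1H-1,2,3-triazol-1-yl in place of hydroxy on a saturated ring carbon, and 4-phenyl-1H-1,2,3-triazol-1-yl in place of hydroxy on a saturated ring carbon gives the count of what changes. Among the measured compounds shown here, three steps bear on it, namely a step that the two limits leave unreadable from compound 2 to compound 3 and a step that the two limits leave unreadable from compound 1 to compound 3 and also a step that the two limits leave unreadable from compound 1 to compound 2 with no size to read in any of them. All three rest on the limit of > 95% in this assay, at which 3 of the 3 values shown sit, and give no sign of a large change. Compound 2 carries a 4-cyanophenyl group and still shows > 95% as a limit, so little or no fall is expected. The estimated change is a number at least 2 percentage points lower from compound 3 to compound 4 (that floor lies within the scatter) in this assay and any shift is expected to be downward. The estimated value for compound 4 is 93% with an expected range from 75% to 100% in this measurement.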

Compound 4, percent of the compound remaining: "unstable" (no number reported)
Nothing numeric was reported for compound 4; no gap can be computed for the estimate.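

Among the compounds shown here, compound 4 is reported only in words and compound 3 only as a limit, so no step between them can be read. On these data alone, how much of compound 4 remains in this assay, and which part of its 4-phenyl-1H-1,2,3-triazol-1-yl group matters, stays open.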